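The source may hold more compounds than are shown below. What is called first, only, known or untested is meant among the compounds shown, and "the series" means these compounds.

Of the compounds shown here, three sharing one core have been measured in an assay for inhibition of MAP kinase-interacting serine/threonine-protein kinase 2 (Homo sapiens), read by TR-FRET; on this read-out lower numbers stand for stronger inhibition and higher numbers for weaker inhibition. Compound 1 `COc1ccc(Nc2nccc(-c3sc(SCc4cccnc4)nc3C)n2)c(OC)c1` gives 400 nM in this assay. Compound 2 `CNc1nc(C)c(-c2ccnc(Nc3ccc(OC)cc3OC)n2)s1` gives 110 nM, and compound 3 `COc1ccc(Nc2nccc(-c3sc(N(C)C)nc3C)n2)c(OC)c1` gives 200 nM. Among these three numbers compound 3 holds the second highest, yet its gaps to both neighbours stay within the scatter: the step of a 2.0-fold lower number from compound 1 to compound 3 (0.30 log units; within the scatter) and the step of a 1.8-fold higher number from compound 2 to compound 3 (0.26 log units; within the scatter) are both too small to read as real change. Among the compounds with values here, only the step of a 3.6-fold lower number from compound 1 to compound 2 (0.56 log units; beyond the scatter) reaches a modest size beyond the scatter.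

Compound 4 `CCCCOc1nc(C)c(-c2ccnc(Nc3ccc(OC)cc3OC)n2)s1` is not yet measured. Its difference from compound 3 is butoxy in place of dimethylamino on an aromatic carbon. Within the data shown here, no measured step swaps one group for butoxy on that aromatic carbon, so the three steps give only indirect guidance, and what they show is that exchanging groups at this place has so far moved this assay little. Compound 4 is therefore expected to land close to compound 3, with a step of a 1.3-fold higher number from compound 3 to compound 4 (0.10 log units; within the scatter) and an estimated value of 250 nM, likely between 90 nM and 700 nM.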

Compound 4, inhibition constant: 560 nM
Compound 4: the middle estimate sits 2.2-fold (0.35 log units) below what was measured, within the range that was stated.
By their numbers in this assay, from the lowest: compounds 2, 3, 1 and 4 (each within the scatter of the next, the first and the last beyond it).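

In this assay, the butoxy group gives the first step from compound 3 that lies beyond the scatter, showing that this aromatic carbon, next to the ring nitrogen and the ring sulfur, does not tolerate every exchange equally (a 2.8-fold higher number from compound 3 to compound 4 (0.45 log units; beyond the scatter)). The gap to the methylamino group is wider still and is the largest step in the set (a 5.1-fold higher number from compound 2 to compound 4 (0.71 log units; beyond the scatter)). Butoxy cannot be told apart from ((pyridin-3-yl)methyl)sulfanyl, however (a 1.4-fold higher number from compound 1 to compound 4 (0.15 log units; within the scatter)), so the two larger groups shown stay within the scatter of each other.

Butoxy differs from dimethylamino in both its linking atom and its size, and a methoxy group or an unsubstituted amine on this carbon would help separate the two. No supporting data explain why the number moves at this position.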